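This account rests on a few compounds, and the source may have more. Where it says the series, first, only, none or still open, it means among the compounds named here.

The values below come from a functional assay on RAW264.7 cells (Mus musculus) for inhibition, read by Griess assay, with a stated time of 20 h; a lower number here means a stronger inhibitor, a higher number a weaker inhibitor (each one is a limit):

- Compound 1 `CCCNC(=O)c1cc(-n2cc(-c3cc(F)cc(F)c3)nn2)ccc1O` gives > 20000 nM (a limit)
- Compound 2 `O=C(c1cc(-n2cc(-c3ccccc3)nn2)ccc1O)N1CCCCC1` gives > 20000 nM (a limit)
- Compound 3 `CCCNC(=O)c1ccc(-n2cc(-c3ccccc3)nn2)cc1O` gives > 20000 nM (a limit)

Compound 3 has only a limit to show, and the limit of > 20000 nM in this assay, at which 3 of the 3 values shown sit, is all that the set offers. Compound 4 `CCCCCCc1cn(-c2ccc(C(=O)NCCC)c(O)c2)nn1` carries hexyl in place of phenyl on an aromatic carbon of a five-membered aromatic ring with 3 nitrogen (hexyl in place of phenyl on an aromatic carbon). Among the compounds with values here, no measured step exists to guide the change. A small gain towards stronger inhibition in this assay is expected, with the estimated step of an at least 1.3-fold lower number from compound 3 to compound 4 (0.12 log units; that floor lies within the scatter) (possibly none beyond the scatter). For compound 4 the estimated value is 15000 nM (expected range 5000 nM to 40000 nM) and it may well come back as a limit again.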

Compound 4, half-maximal inhibitory concentration: > 20000 nM
Compound 4: no number, only a limit; the forecaster's own chance of this, stated with the estimate: 55%; middle value at least 1.3-fold (0.12 log units) from the limit.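

Compound 3 and compound 4 both return only a limit, and no step between them can be read: the limit of > 20000 nM in this assay, at which 4 of the 4 values shown sit.

The compounds shown leave open which change to the shared core, if any, would give a numerical value rather than a limit.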